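The source may report more compounds than this note shows. Statements on the series, on what has been measured and on what is new or still open speak of the compounds shown alone.

Measured so far in a functional assay on SCC-7 cells (Mus musculus) for inhibition; on this read-out higher numbers stand for weaker inhibition and lower numbers for stronger inhibition:
- Compound 1 `COc1cccc2c1[n+]([O-])nc(N)[n+]2[O-]`: 13500 nM
- Compound 2 `Nc1n[n+]([O-])c2c(F)cccc2[n+]1[O-]`: 1200 nM
- Compound 3 `Nc1n[n+]([O-])c2cc(Cl)ccc2[n+]1[O-]`: 610 nM

Compound 3 and compound 2 lie within the usual scatter of each other, and compound 1 carries a clearly higher number than either of them. The next compound, compound 4 `Nc1n[n+]([O-])c2cc([N+](=O)[O-])ccc2[n+]1[O-]`, keeps the core of compound 3 and changes a single group: nitro in place of chloro on an aromatic carbon.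

Among the compounds with values here, only one measured step bears on this change, and only loosely. It is an 11-fold lower number from compound 1 to compound 2 (1.05 log units; beyond the scatter), a large step beyond the scatter, made by putting fluoro in place of methoxy on an aromatic carbon. That step shows that swapping one group on the core can move the number a long way in this assay. However, it involves neither chloro nor nitro, and no measured compound carries a nitro group, so it gives no direct size for this swap. The expectation is therefore a modest shift towards a lower number, not clearly beyond the scatter, held with wide uncertainty in both directions. The estimated change is a 1.5-fold lower number from compound 3 to compound 4 (0.18 log units; within the scatter). For compound 4 the expected value is 400 nM, with an estimated range from 100 nM to 1500 nM.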

Compound 4, half-maximal inhibitory concentration: 700 nM
The estimate for compound 4 lay 1.8-fold (0.24 log units) below the measured number, and the stated range covers the measured number.
By their numbers in this assay, from the lowest: compounds 3, 4 and 2 (each within the scatter of the next); then compound 1.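

In this assay the exchange of chloro for nitro gives a 1.1-fold higher number from compound 3 to compound 4 (0.06 log units; within the scatter) and so stays within the scatter. On this aromatic carbon, a group of one heavy atom with no hydrogen-bond acceptors has given way to one of three heavy atoms with two hydrogen-bond acceptors, and the read-out does not separate compound 3 from compound 4. A single swap on the shared core therefore need not move the number far, which stands in contrast to the large step seen with other groups, an 11-fold lower number from compound 1 to compound 2 (1.05 log units; beyond the scatter) in the same read-out. The data at hand offer no explanation for why these two groups give such similar numbers.

Only chloro and nitro are shown at this place, so two groups cannot tell whether the number stays this steady across a wider range of substituents. An amine, a carboxylic acid or a longer alkyl chain on the same carbon could show whether this position tolerates change generally or whether these two groups simply happen to give matching results.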